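Fluoro-Methylphenyl Replaces Methyl on the Saturated Ring Carbon

A few compounds are considered here, and "the series" means these few. Any claim that something is new, unique, unknown or untested is made for them only; others in the source may bear on it.

Measured compounds:
compound 1 `CC1C(=O)N(C)c2cnc(Nc3ccc(S(N)(=O)=O)cc3)nc2N1C`: 313 nM
compound 2 `CN1C(=O)C(c2cccc(F)c2)N(C)c2nc(Nc3ccc(S(N)(=O)=O)cc3)ncc21`: 134 nM
compound 3 `CN1C(=O)C(c2cccc(C(F)(F)F)c2)N(C)c2nc(Nc3ccc(S(N)(=O)=O)cc3)ncc21`: 2710 nM

In an assay on Sf9 cells for inhibition of serine/threonine-protein kinase 4 (Homo sapiens), read by luminescence and ADP-Glo, with a stated time of 1 h, in the presence of a further agent that is not named here (a higher number here means a weaker inhibitor, a lower number a stronger inhibitor), compound 1 gives 313 nM, the second highest of the three numbers. Compound 4 `Cc1ccc(F)cc1C1C(=O)N(C)c2cnc(Nc3ccc(S(N)(=O)=O)cc3)nc2N1C` differs from compound 1 by 5-fluoro-2-methylphenyl in place of methyl on a saturated ring carbon. For the measured compounds named here, two measured steps bear on this change, both starting from the same methyl parent: a 2.3-fold lower number from compound 1 to compound 2 (0.37 log units; beyond the scatter) and an 8.7-fold higher number from compound 1 to compound 3 (0.94 log units; beyond the scatter). An aryl group on that saturated ring carbon has therefore moved the number in both directions, and a 5-fluoro-2-methylphenyl group has no measured counterpart among these compounds. The resulting step is expected to be a 1.3-fold higher number from compound 1 to compound 4 (0.11 log units; within the scatter), with considerable uncertainty. Compound 4 is estimated to give 400 nM in this assay, within a range from 100 nM to 1600 nM.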

Compound 4, half-maximal inhibitory concentration: 168 nM
Estimate against measurement, compound 4: 2.4-fold (0.38 log units) above, and the stated range covers the measured number.
By their numbers in this assay, from the lowest: compounds 2, 4 and 1 (each within the scatter of the next, the first and the last beyond it); then compound 3.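

Adding methyl to the aromatic ring of the fluorophenyl group gives a 1.3-fold higher number from compound 2 to compound 4 (0.10 log units; within the scatter) and so leaves the number unchanged within the scatter. The 5-fluoro-2-methylphenyl group also gives a 1.9-fold lower number from compound 1 to compound 4 (0.27 log units; within the scatter) and so shows that this larger aryl group on the saturated ring carbon can match the methyl parent. Replacing 3-(trifluoromethyl)phenyl with it gives a 16-fold lower number from compound 3 to compound 4 (1.21 log units; beyond the scatter) and so shows that the high number of compound 3 does not extend to every aryl group at this position. Nothing measured here explains these differences.
The compounds shown leave open how an unsubstituted phenyl, a methoxyphenyl or an aminophenyl group would read on this carbon.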